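Amide series notes: estimate for compound 4

The source may hold more compounds than are shown below. What is called first, only, known or untested is meant among the compounds shown, and "the series" means these compounds.

Measured so far:
Compound 1 `COc1ccc(CNC(=O)/C=C/c2coc3cc(O)ccc3c2=O)cc1` gives 10000 nM in a functional assay (QGY7701 cells, Homo sapiens) for inhibition, read by MTT assay, with a stated time of 48 h; on this read-out higher numbers stand for weaker inhibition and lower numbers for stronger inhibition.
Compound 2 `O=C(/C=C/c1coc2cc(O)ccc2c1=O)NCc1ccccc1` gives 63000 nM in this assay.
Compound 3 `COc1cccc(NC(=O)/C=C/c2coc3cc(OC)ccc3c2=O)c1` gives 39100 nM in this assay.

Compound 3 stands second highest of the three numbers. Its nearest neighbour is compound 2, whose value lies within the scatter of that of compound 3; its furthest is compound 1, whose lower value lies beyond the scatter.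

Compound 4 `CCOc1ccc(NC(=O)/C=C/c2coc3cc(OC)ccc3c2=O)cc1` differs from compound 3 by 4-ethoxyphenyl in place of 3-methoxyphenyl on an amide-type nitrogen. For the measured compounds named here, the only measured step is a 6.3-fold higher number from compound 1 to compound 2 (0.80 log units; beyond the scatter), which removes a methoxy from the aromatic ring of the amide part in a benzyl-linked compound, not an aryl-linked one; it bears on the present change only loosely, since compound 3 and compound 4 both keep an alkoxy on that ring and differ in which alkoxy it is and where it sits, for which no step is known. No step beyond the scatter is therefore expected in this assay, and the expected step is a 1.4-fold lower number from compound 3 to compound 4 (0.15 log units; within the scatter). Compound 4 is estimated at 28000 nM, with a range from 9000 nM to 90000 nM.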

Compound 4, half-maximal inhibitory concentration: > 100000 nM
Compound 4 gave a limit, no number; the forecaster's own chance of this, stated with the estimate: 15%; middle value at least 3.5-fold (0.55 log units) from the limit.
By their numbers in this assay, from the lowest: compound 1; then compounds 3 and 2 (each within the scatter of the next). At a limit, above all of these: compound 4.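

Replacing 3-methoxyphenyl with 4-ethoxyphenyl on the amide-type nitrogen gives an at least 2.5-fold higher number from compound 3 to compound 4 (0.40 log units; beyond the scatter) in this assay, so this position is not indifferent to which alkoxy-bearing phenyl it carries, even though both groups have one aromatic ring and the same counted donors and acceptors. Compound 4 gives > 100000 nM, which is a limit of the assay and not a number. The full size of the step therefore stays unread, and only the limit stands: the limit of > 100000 nM in this assay, at which 1 of the 4 values shown sits.

The pair changes the alkoxy group and its place on the ring at once, so the two changes cannot be separated. The compounds shown also leave open how this assay would read with an amine or a carboxylic acid on that phenyl ring.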